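A Hydroxymethyl Group Added to a Biaryl Amide

This account rests on a few compounds, and the source may have more. Where it says the series, first, only, none or still open, it means among the compounds named here.

Of the compounds shown here, three of a shared amide core have been tested in a functional assay on KYSE-70 cells for antiproliferative activity against KYSE-70 cell line (Homo sapiens), read by MTT assay, with a stated time of 72 h; on this read-out lower numbers stand for stronger inhibition and higher numbers for weaker inhibition. Compound 1 `O=C(Nc1ccccn1)c1cc(=O)[nH]c2cc(Br)ccc12` gives 11000 nM in this assay. Compound 2 `O=C(Nc1cc(F)c(F)c(F)c1)c1cc(=O)[nH]c2cc(Br)ccc12` returns only a limit of the assay, > 20000 nM, rather than a number (the limit of > 20000 nM in this assay, at which 1 of the 3 values shown sits). Compound 3 `O=C(Nc1cccc(F)c1)c1cc(=O)[nH]c2cc(-c3ccc(F)cc3)ccc12`, which carries a 4-fluorophenyl group in place of the bromine, gives 3300 nM in this assay. Of the two numbers shown, compound 3 has the lowest; the nearest is compound 1, and the gap between them is beyond the usual scatter of repeated measurements.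

The next compound, compound 4 `O=C(Nc1cccc(F)c1)c1cc(=O)[nH]c2cc(-c3ccc(F)c(CO)c3)ccc12`, keeps the whole of compound 3 and differs in a single place: hydroxymethyl in place of hydrogen on an aromatic carbon. Among the compounds with values here, no pair of measured compounds shows this particular change, so its effect in this assay is not yet known. Within the data shown here, with no direct precedent, a small step is expected rather than a large one, and in this assay it is expected to fall within the usual scatter.

For compound 4 the estimated value in this assay is 2800 nM, with a likely range from 900 nM to 9000 nM. The step of a 1.2-fold lower number from compound 3 to compound 4 (0.07 log units; within the scatter) that this estimate implies is expected to stay within the scatter.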

Compound 4, half-maximal inhibitory concentration: > 20000 nM
Compound 4: a limit, no number; the forecaster's own chance of this, stated with the estimate: 5%; at least 7.1-fold (0.85 log units) between middle value and limit.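

Replacing a hydrogen on the 4-fluorophenyl group with hydroxymethyl, ortho to the fluoro group, gives in this assay an at least 6.0-fold higher number from compound 3 to compound 4 (0.78 log units; beyond the scatter). Within the data shown here, this is the first pair that differs in only one place, and it shows that this carbon is not a neutral spot: a change of only 2 heavy atoms here is enough to cost compound 3 its measurable activity in this read-out. The reading for compound 4 is a limit of the assay and not a number, so the step has a minimum size but no known full size, and the series now has a second compound at that limit: the limit of > 20000 nM in this assay, at which 2 of the 4 values shown sit.

On these data alone, it remains open whether a methyl, a methoxy or an aminomethyl group on this same carbon would behave like hydroxymethyl, which would help separate the part played by the oxygen from that of the added carbon. It is also open whether hydroxymethyl would have the same effect on another carbon of this ring, since the compounds shown cover only this one place.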